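Ethynyl to thiophen-3-yl exchange on the shared core

The source may hold more compounds than are shown below. What is called first, only, known or untested is meant among the compounds shown, and "the series" means these compounds.

Measured compounds:
compound 1, `C#Cc1cn([C@@H]2O[C@H](CO)[C@@H](O)[C@H]2O)c2ncnc(C)c12`: 1440 nM in an ADME assay on MRC5 cells (Homo sapiens), read by MTT assay, with a stated time of 72 h; on this read-out lower numbers stand for stronger inhibition and higher numbers for weaker inhibition
compound 2, `C#Cc1cn([C@@H]2O[C@H](CO)[C@@H](O)[C@H]2O)c2ncnc(NC)c12`: > 100000 nM in this assay

Compound 1 holds the only number shown in this assay. Compound 2 sits at the limit of > 100000 nM in this assay, at which 1 of the 2 values shown sits, which is a limit of the assay and not a number. Going by the values given here, the single measured step, an at least 69-fold higher number from compound 1 to compound 2 (1.84 log units; beyond the scatter), concerns methylamino in place of methyl and does not touch the position changed in the present step.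

Compound 3, `Cc1ncnc2c1c(-c1ccsc1)cn2[C@@H]1O[C@H](CO)[C@@H](O)[C@H]1O`, differs from compound 1 as follows: thiophen-3-yl in place of ethynyl on an aromatic carbon. No measured step bears on this exchange, so neither its size nor its direction can be read from the numbers shown; compound 2 does show that a single change on the shared core can move the read-out in this assay by a large step, which argues for a wide range here. For compound 3 the expected step from compound 1 is a 2.1-fold higher number from compound 1 to compound 3 (0.32 log units; beyond the scatter), leaning toward a somewhat higher number. Compound 3 is estimated at 3000 nM, with a range from 500 nM to 20000 nM.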

Compound 3, half-maximal inhibitory concentration: > 100000 nM
Compound 3 gave a limit, no number; the forecaster's own chance of this, stated with the estimate: 15%; middle value at least 33-fold (1.52 log units) away from the limit.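

On an aromatic carbon two ring bonds from the ring nitrogen, replacing ethynyl with thiophen-3-yl gives an at least 69-fold higher number from compound 1 to compound 3 (1.84 log units; beyond the scatter), so this position, untouched by the earlier step, also responds strongly to a single change. In this assay compound 3 reads as a limit of the assay and not a number: the limit of > 100000 nM in this assay, at which 2 of the 3 values shown sit. The full size of this step therefore stays unknown, and ethynyl is the only group at this position shown here with a number, so a change at this position and the methylamino change in the other place each carry the read-out from the number of compound 1 to a limit.

The compounds shown leave open whether a nitrile, a propynyl chain or a phenyl ring at this position would keep a number close to that of compound 1, and so whether the outcome tracks the size of the group, the thiophene ring itself or the loss of the triple bond. Compound 2 and compound 3 differ in two places, so they give no ranking of the two changes against each other.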